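This account rests on a few compounds, and the source may have more. Where it says the series, first, only, none or still open, it means among the compounds named here.

Compound 3 `O=C([C@@H]1CCCN(S(=O)(=O)c2ccc(S(=O)(=O)C3CC3)cc2)C1)N1CCC(F)(F)CC1` carries the highest number of the three measured compounds in a functional assay on BXPC-3 cells (Homo sapiens) for inhibition, read by MTT assay, with a stated time of 7 days; on this read-out lower numbers stand for stronger inhibition and higher numbers for weaker inhibition: compound 3 gives 129 nM, compound 2 `O=C([C@@H]1CCCN(S(=O)(=O)c2ccc(S(=O)(=O)C3CCC3)cc2)C1)N1CCC(F)(F)CC1` gives 78 nM, and compound 1 `CCC(CC)S(=O)(=O)c1ccc(S(=O)(=O)N2CCC[C@@H](C(=O)N3CCC(F)(F)CC3)C2)cc1` gives 40 nM. Compound 4 `CN(C)S(=O)(=O)c1ccc(S(=O)(=O)N2CCC[C@@H](C(=O)N3CCC(F)(F)CC3)C2)cc1` differs from compound 3 by dimethylamino in place of cyclopropyl on a sulfonyl sulfur. Among the compounds with values here, the steps that touch the same sulfonyl sulfur are a 3.2-fold higher number from compound 1 to compound 3 (0.51 log units; beyond the scatter) and a 1.7-fold higher number from compound 2 to compound 3 (0.22 log units; within the scatter), with a 2.0-fold higher number from compound 1 to compound 2 (0.29 log units; within the scatter) between the two ring compounds; smaller groups on that sulfur went with higher numbers, though no measured step replaces a carbon ring by a nitrogen group. Compound 4 is therefore expected to give a number near or somewhat above that of its parent, an estimated step of a 1.4-fold higher number from compound 3 to compound 4 (0.14 log units; within the scatter). Compound 4 is estimated at 180 nM, within 70 nM to 450 nM.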

Compound 4, half-maximal inhibitory concentration: 560 nM
Beside the measured number, compound 4's estimate is 3.1-fold (0.49 log units) below it; the measured number lies above the stated range.
By their numbers in this assay, from the lowest: compounds 1, 2 and 3 (each within the scatter of the next, the first and the last beyond it); then compound 4.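

In this assay dimethylamino on a sulfonyl sulfur comes with a 4.3-fold higher number from compound 3 to compound 4 (0.64 log units; beyond the scatter) even though cyclopropyl and dimethylamino each hold 3 heavy atoms, so the link between smaller groups and higher numbers seen among the carbon groups does not cover this change. The distance grows to a 7.2-fold higher number from compound 2 to compound 4 (0.86 log units; beyond the scatter) and to a 14-fold higher number from compound 1 to compound 4 (1.15 log units; beyond the scatter) and sets compound 4 beyond the scatter of all three carbon-bearing compounds.

Going by these compounds, whether the nitrogen or the open chain matters stays open: isopropyl or azetidin-1-yl on that sulfur would separate the two. The compounds shown hold no evidence on the cause of this step.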